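Replacing the phenyl on the ketone with a fused heteroaromatic ring

The compounds below may be only part of what the source reports. "The series", "measured", "known", "first", "only" and "open" are said of these compounds alone.

Measured so far in an assay on isolated protein for inhibition of Fatty-acid amide hydrolase 1 (Homo sapiens); a lower number here means a stronger inhibitor, a higher number a weaker inhibitor:
- compound 1 `CCCCCCCC/C=C\CCCCCCC(=O)c1ncc(-c2ccoc2)o1` gives 610 nM
- compound 2 `CCCCCCCC/C=C\CCCCCCC(=O)c1nc2cnccc2o1` gives 7.2 nM
- compound 3 `CCCCCCCC/C=C\CCCCCCC(=O)c1ccccc1` sits at a limit of the assay, > 100000 nM

Compound 3 is therefore the weakest point on this list: for it the assay reports only a limit, (the limit of > 100000 nM in this assay, at which 1 of the 3 values shown sits), and no number. Compound 4 `CCCCCCCC/C=C\CCCCCCC(=O)c1nc2ncccc2o1` differs from compound 3 in a single place: a group of 9 heavy atoms (6 carbon, 2 nitrogen, 1 oxygen; one five-membered aromatic ring with 2 hetero atoms, one six-membered aromatic ring with 1 hetero atom) in place of a group of 6 heavy atoms (6 carbon; one six-membered aromatic ring of carbon only), on a carbonyl carbon. For the measured compounds named here, the one measured step that bears on this change runs the other way, from a fused ring of the same kind to the plain phenyl, and it was an at least 13000-fold higher number from compound 2 to compound 3 (4.14 log units; beyond the scatter). Putting a fused ring of nine heavy atoms back onto the carbonyl carbon is expected to reverse most of that loss, so a large downward step in this assay is expected, of about an at least 5000-fold lower number from compound 3 to compound 4 (3.69 log units; beyond the scatter). Compound 4 is estimated at 20 nM, with a likely range from 3 nM to 200 nM.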

Compound 4, inhibition constant: 2.3 nM
Compound 4: middle estimate off by 8.7-fold (0.94 log units), on the high side; the measured number lies below the stated range.
By their numbers in this assay, from the lowest: compound 4; then compound 2; then compound 1. At a limit, above all of these: compound 3.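

In this assay, an at least 43000-fold lower number from compound 3 to compound 4 (4.63 log units; beyond the scatter) shows that the return of strong inhibition on this carbonyl carbon is not unique to the fused ring of compound 2. From the compounds shown here alone, the true size of that step stays unknown, since compound 3 is reported only as a limit: the limit of > 100000 nM in this assay, at which 1 of the 4 values shown sits. The comparison a 3.1-fold lower number from compound 2 to compound 4 (0.50 log units; beyond the scatter) adds something new: two fused rings with identical atom counts are not interchangeable, so the arrangement of atoms within the ring affects the result, although this change is far smaller than the one from phenyl.

The compounds shown do not say why these two rings differ. They also leave open whether a chlorine or a carboxylic acid on the fused ring, or a shorter chain on the ketone, would keep this level of inhibition.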